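Aryl in place of cycloalkyl on the ring nitrogen

The source may report more compounds than this note shows. Statements on the series, on what has been measured and on what is new or still open speak of the compounds shown alone.

In a functional assay on KB cells (Homo sapiens) for cytotoxicity, read by MTT assay, with a stated time of 72 h (a lower number here means that less compound is needed, a higher number that more compound is needed for the effect), compound 3 `O=c1cc(NC2CCCCC2)cc(-c2ccccc2)o1` gives 16 uM, the highest of the two numbers shown, while compound 2 `COc1ccc(Nc2cc(-c3ccccc3)oc(=O)c2)cc1` gives 0.16 uM. Compound 1 `O=c1cc(NC2CC2)cc(-c2ccccc2)o1` returns > 30 uM, which is a limit of this assay and not a number. Between the two cycloalkyl compounds, the step of an at least 1.8-fold lower number from compound 1 to compound 3 (0.27 log units; that floor lies within the scatter) is small. Compound 4 `O=c1cc(Nc2ccc(Br)cc2)cc(-c2ccccc2)o1` carries 4-bromophenyl in place of cyclohexyl on a nitrogen on an aromatic ring. Among the measured compounds shown here, no measured step covers an aryl-for-cycloalkyl swap directly; the only guide is that compound 2, the one aryl-bearing compound, sits far lower than compound 3 in this assay. A marked decrease is therefore expected for compound 4. The estimate for compound 4 is 0.4 uM, with a range from 0.06 uM to 3 uM, which implies an expected step of a 40-fold lower number from compound 3 to compound 4 (1.60 log units; beyond the scatter).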

Compound 4, concentration for half-maximal effect: 0.32 uM
Compound 4: middle estimate off by 1.3-fold (0.10 log units), on the high side; the measured number falls inside the stated range.
By their numbers in this assay, from the lowest: compounds 2 and 4 (each within the scatter of the next); then compound 3. At a limit, above all of these: compound 1.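

In this assay, a direct step from cycloalkyl to aryl on the nitrogen is now available, and it is large: a 50-fold lower number from compound 3 to compound 4 (1.70 log units; beyond the scatter). Bromo and methoxy on the aryl ring cannot be told apart here: a 2.0-fold higher number from compound 2 to compound 4 (0.30 log units; within the scatter). The step of an at least 93-fold lower number from compound 1 to compound 4 (1.97 log units; beyond the scatter) is only a floor, as compound 1 stands at a limit: the limit of > 30 uM in this assay, at which 1 of the 4 values shown sits.

As far as these compounds go, whether an aromatic ring must sit directly on the nitrogen remains open, and a benzyl group there would test this. Also open, from the compounds shown here alone, is how a carboxylic acid or an amine in place of bromo would read.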